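This account rests on a few compounds, and the source may have more. Where it says the series, first, only, none or still open, it means among the compounds named here.

Measured so far:

- Compound 1, `NC(=O)c1nc2ccccn2c1[N+](=O)[O-]`: -0.54 in a physicochemical assay for lipophilicity, measured as octanol-water partition; on this read-out lower numbers stand for lower lipophilicity and higher numbers for higher lipophilicity
- Compound 2, `Cc1cccc2nc(C(N)=O)c([N+](=O)[O-])n12`: 0.695 in this assay

Compound 1 has the lower of the two measured numbers, and compound 2 is the nearer, indeed the only, neighbour: a number 1.24 log units higher from compound 1 to compound 2 (beyond the scatter). For the measured compounds named here, that one measured step concerns a methyl in place of a hydrogen on an aromatic carbon, and it is the only step the data hold.

Compound 3, `N#Cc1nc2ccccn2c1[N+](=O)[O-]`, has not yet been measured in this assay. It differs from compound 1 in one place: cyano in place of carbamoyl on an aromatic carbon. Going by the values given here, no measured step involves this change, so the methyl step of compound 2 offers no direct guide; it shows only that a single small change on this core can move the number well beyond the scatter. With the carbamoyl gone and a cyano in its place, the count of hydrogen-bond donors falls to none, and a rise in this assay is expected, though of uncertain size. The step expected for compound 3 from this change is estimated as a number 0.84 log units higher from compound 1 to compound 3 (beyond the scatter). Compound 3 is therefore estimated at 0.3, with a range from -0.2 to 0.8.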

Compound 3, partition coefficient: 0.692
The estimate for compound 3 lay 0.39 log units below the measured number; measured number inside the range.
By their numbers in this assay, from the lowest: compound 1; then compounds 3 and 2 (each within the scatter of the next).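

In this assay, for the compounds shown here, putting a cyano in place of the carbamoyl gives a number 1.23 log units higher from compound 1 to compound 3 (beyond the scatter), the first measured step at this aromatic carbon, the one next to the ring atom that bears a nitro group. Going by these compounds alone, until now the only measured change was the methyl of compound 2, at a different place on the shared core; this result shows that the carbamoyl position can also move the number by a large step, in a swap where the carbamoyl, which carries a hydrogen-bond donor, gives way to a cyano, which carries none. That difference in donors, like the difference in heavy atoms, is a plain count from the two structures, and nothing measured here ties the step to either one.

The compounds shown leave open where other groups at this same position, such as a carboxylic acid, an amine or a methyl ester, would stand in this assay. They also leave open whether the same swap would give a step of similar size on the core of compound 2, which carries the methyl.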